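The source may report more compounds than this note shows. Statements on the series, on what has been measured and on what is new or still open speak of the compounds shown alone.

The measured compounds:

compound 1, `O=S(=O)(/C=C/c1ccccn1)c1ccccc1F`, 1050 nM
compound 2, `O=S(=O)(/C=C/c1cccc(Cl)n1)c1ccccc1F`, 898 nM
compound 3, `O=S(=O)(/C=C/c1cccnc1)c1ccccc1Cl`, 2850 nM

The three compounds were tested in an assay on U2OS cells for activation of nuclear factor erythroid 2-related factor 2 (Homo sapiens), read by beta-arrestin recruitment, with a stated time of 6 h; on this read-out higher numbers stand for an effect only at larger amounts of compound and lower numbers for an effect already at smaller amounts. Compound 1 gives 1050 nM in this assay, and compound 2 gives 898 nM. The two share a core and differ by chloro in place of hydrogen on an aromatic carbon; this step amounts to a 1.2-fold lower number from compound 1 to compound 2 (0.07 log units; within the scatter). Compound 3, with 2850 nM, has the highest number of the three, and its difference from the core of compound 1 is not broken down here.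

Compound 4, `O=S(=O)(/C=C/c1ccc(Cl)nc1)c1ccccc1Cl`, has not yet been measured. It differs from compound 3 by chloro in place of hydrogen on an aromatic carbon. Within the data shown here, this is the same kind of change as the one from compound 1 to compound 2, though not the same: in compound 2 the entering chloro is meta to a large group, whereas in compound 4 it is para to a large group, and the core is that of compound 3 rather than of compound 1.

Among the measured compounds shown here, the only measured instance of this kind of change is a 1.2-fold lower number from compound 1 to compound 2 (0.07 log units; within the scatter), a step within the scatter. On that basis the step from compound 3 to compound 4 is expected to be small as well, about a 1.2-fold lower number from compound 3 to compound 4 (0.07 log units; within the scatter). For compound 4 in this assay an estimate of 2400 nM is therefore given, with a likely range from 1200 nM to 5000 nM, the width reflecting that the change has been seen once, on a different core and at a different place.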

Compound 4, half-maximal effective concentration: 1630 nM
Compound 4: middle estimate off by 1.5-fold (0.17 log units), on the high side; the range from low to high includes it.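

In this assay, chloro in place of hydrogen on an aromatic carbon gives a 1.7-fold lower number from compound 3 to compound 4 (0.24 log units; within the scatter), and this step does not stand apart from the earlier one: the same change on two cores in this assay, a 1.2-fold lower number (0.07 log units; within the scatter) from compound 1 to compound 2 and a 1.7-fold lower number (0.24 log units; within the scatter) from compound 3 to compound 4, 1.5-fold (0.17 log units) apart, within the scatter of two such steps. On the two cores shown, then, the change carries over as a small step, even though the chloro does not stand at the same place in compound 2 and compound 4. This does not show that chloro lowers the number at all, since each step lies within the scatter, and two instances cannot show that the step would stay small on any further core or at any further place on the ring.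

The compounds shown leave open whether another group at the place next to the ring nitrogen, such as a methyl, a methoxy, an amine, a nitrile, a carboxylic acid or a longer chain, would give a larger step than chloro does. They also leave open whether chloro para to a large group on the core of compound 1 would give a step like the one seen on the core of compound 3, which would separate the effect of the place from that of the core.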